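A few compounds are considered here, and "the series" means these few. Any claim that something is new, unique, unknown or untested is made for them only; others in the source may bear on it.

Working notes on the series. The read-out throughout is an assay on HEK293 cells for positive allosteric modulation of metabotropic glutamate receptor 2 (Rattus norvegicus), read by thallium flux, with a stated time of 2.5 min; a higher number here means a larger maximal response, a lower number a smaller maximal response. Compound 1 `Cc1c(OCCCCOc2ccc(C(=O)O)cc2)ccc(C(=O)CC2CCCC2)c1O` is measured there; in this assay compound 1 gives 82.6%. Going by the values given here, the only other measured member is compound 2 `Cc1cc(C(=O)O)ccc1OCCCCOc1ccc(C(=O)CC(C)C)c(O)c1C`, which in this assay gives 83.9%. Among the compounds with values here, the two values lie within the scatter of each other, so on the numbers so far compound 1 and compound 2 cannot be told apart, and the series offers no step between measured compounds to calibrate the effect of a change to the linker.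

Compound 3 `Cc1c(OCCCCOCOc2ccc(C(=O)O)cc2)ccc(C(=O)CC2CCCC2)c1O` is not yet measured. Its difference from compound 1 is (4-carboxyphenoxy)methyl in place of 4-carboxyphenyl on an oxygen on a saturated carbon, that is, the chain between the two aromatic parts is lengthened by one carbon and one oxygen while the ends stay the same. Within the data shown here, with no comparable step in hand, the maximal response is expected to stay at the level of compound 1: the step of a number 2.6 percentage points lower from compound 1 to compound 3 (within the scatter) in this assay is expected to be none beyond the scatter. For compound 3 the estimate in this assay is 80%, with a range from 60% to 100%.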

Compound 3, largest response reached (reported as percent of maximum), in percent of the reference or control that the assay uses: 95.4%
Compound 3: middle estimate off by 15.4 percentage points, on the low side; low and high end bracket the measured number.
By their numbers in this assay, from the lowest: compounds 1 and 2 (each within the scatter of the next); then compound 3.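

In this assay, going by these compounds alone, the change of 4-carboxyphenyl to (4-carboxyphenoxy)methyl, on an oxygen on a saturated carbon, gives the first step that can be read: a number 12.8 percentage points higher from compound 1 to compound 3 (beyond the scatter). This position therefore accepts the larger group, with 11 heavy atoms against 9 and one more hydrogen-bond acceptor, and the maximal response is not lost; the benzoic acid end remains in place, now carried further out along the chain, and the rest of the core of compound 1 stays unchanged. Nothing measured on these compounds bears on the reason for this gain.

A single step cannot separate the contribution of the added oxygen from that of the added chain length, and a plain carbon chain of the same length, or an amine in place of the added oxygen, would draw that distinction. Also open, going by these compounds, is whether the same change gives a similar step on compound 2, whose ketone carries a different group, and whether a still longer chain would raise the response further or lower it.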